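The source may report more compounds than this note shows. Statements on the series, on what has been measured and on what is new or still open speak of the compounds shown alone.

Within the data shown here, two measured compounds define the series so far. Compound 1 `O[C@@H]1[C@@H](O)CN[C@H]1c1ccc(F)cc1` gives 30% in an assay on lysosomes for inhibition of Maltase-glucoamylase (Homo sapiens), read by spectrophotometry, tested at 1000 uM; a lower number here means less inhibition, a higher number more inhibition at the concentration tested (going by the name of the read-out). Compound 2 `O[C@H]1[C@H](O)CN[C@@H]1c1ccc(-c2ccccc2)cc1` gives 2.9% in this assay, the lowest of the two numbers, with compound 1 standing higher by a margin beyond the usual scatter of repeated measurements. Among the measured compounds shown here, no step between two measured compounds that differ in a single place is available, so nothing yet shows how one change alone moves this read-out.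

The next compound to be measured is compound 3 `O[C@H]1[C@H](O)CN[C@@H]1c1ccc(F)cc1`. Relative to compound 2 the change is fluoro in place of phenyl on an aromatic carbon. For the measured compounds named here, with no measured single-point step to lean on, the expectation for the step from compound 2 to compound 3 is an increase, a number 12.1 percentage points higher from compound 2 to compound 3 (beyond the scatter), judged from the low value of compound 2 2.9% and the higher value of compound 1 30%, which carries the fluoro rather than the phenyl. Compound 3 is accordingly estimated at 15% in this assay, with a range from 0% to 35%. The measurement follows.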

Compound 3, a percentage reported as inhibition, at one concentration (the size of the read-out at that concentration, not a potency): 13.4%
For compound 3 the middle estimate is 1.6 percentage points above the measured one; the measured number falls inside the stated range.
By their numbers in this assay, from the lowest: compound 2; then compound 3; then compound 1.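

In this assay, among these compounds, fluoro in place of phenyl on an aromatic carbon, para to a group of 7 heavy atoms, gives the first single-place step: a number 10.5 percentage points higher from compound 2 to compound 3 (beyond the scatter). Inverting all three stereocentres also moves the read-out, with a number 16.6 percentage points lower from compound 1 to compound 3 (beyond the scatter), so the mirror images do not read alike. That gap can be assigned to configuration alone, and the ground for this is: the fact that compounds 1 and 3 differ only in the configuration as drawn

Still open, from the compounds shown here alone, is how a methoxy group, an amine or a carboxylic acid on that aromatic carbon would compare with fluoro and phenyl, and whether the step from phenyl to fluoro keeps its size in the configuration of compound 1. Also open is which of the three stereocentres accounts for the difference between the mirror images.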